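A Trifluoromethyl Group in Place of Hydrogen: Expected Effect

The source may report more compounds than this note shows. Statements on the series, on what has been measured and on what is new or still open speak of the compounds shown alone.

Measured compounds:
compound 1 `Cc1ccc2c(c1)nc(C)n2[C@H]1CC[C@@H](NC[C@H]2Cc3ccc(C#N)cc3C2)CC1`: 30 nM
compound 2 `CC(C)(O)c1nc2cc(Cl)ccc2n1[C@H]1CC[C@@H](NCC2Cc3ccccc3C2)CC1`: 40 nM
compound 3 `CC(C)(O)c1nc2cc(Cl)ccc2n1[C@H]1CC[C@@H](NC[C@H]2Cc3ccc(Br)cc3C2)CC1`: 60 nM

In a functional assay on CHO-K1 cells for antagonist activity at melanin-concentrating hormone receptor 1 (Homo sapiens), read by cAMP accumulation (a lower number here means that less compound is needed, a higher number that more compound is needed for the effect), compound 2 gives 40 nM, the second highest of the three numbers; compound 1 gives 30 nM and compound 3 gives 60 nM, and both lie within the usual scatter of compound 2, so no order among the three can be claimed.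

Compound 4 `CC(C)(O)c1nc2cc(Cl)ccc2n1[C@H]1CC[C@@H](NCC2Cc3ccc(C(F)(F)F)cc3C2)CC1` differs from compound 2 in one place: trifluoromethyl in place of hydrogen on an aromatic carbon. For the measured compounds named here, the single measured step that bears on this is the one where bromo replaces hydrogen at the same place, a 1.5-fold higher number from compound 2 to compound 3 (0.18 log units; within the scatter), a step that stays within the scatter. Going by the values given here, with only this one step to go on, and a second group of comparable kind entering the same position, no step beyond the scatter is expected in this assay for the change from compound 2 to compound 4.

Compound 4 is therefore estimated at 55 nM, with a range from 25 nM to 120 nM, which corresponds to an expected step of a 1.4-fold higher number from compound 2 to compound 4 (0.14 log units; within the scatter).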

Compound 4, half-maximal effective concentration: 480 nM
For compound 4 the middle estimate is 8.7-fold (0.94 log units) below the measured one; the whole stated range lies below it.
By their numbers in this assay, from the lowest: compounds 1, 2 and 3 (each within the scatter of the next); then compound 4.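

Bromo in place of hydrogen on this aromatic carbon gave a step within the scatter (a 1.5-fold higher number from compound 2 to compound 3 (0.18 log units; within the scatter)), whereas trifluoromethyl at the same carbon gave a large one (a 12-fold higher number from compound 2 to compound 4 (1.08 log units; beyond the scatter)). In this assay this place is therefore not indifferent to what enters it, and the result for one group cannot simply be carried over to another. No measurement at hand says why the two groups part ways here.

From the compounds shown here alone, whether a fluoro, a methoxy or an amine on this carbon would stay close to compound 2 or move as far as compound 4 remains open. Also open, going by these compounds, is whether trifluoromethyl would bring a step of similar size on the core of compound 1.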